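Methyl on the indole nitrogen of compound 1

The compounds below may be only part of what the source reports. "The series", "measured", "known", "first", "only" and "open" are said of these compounds alone.

Measured so far:
- compound 1, `CCOC(=O)c1cccc(-c2ccc3[nH]ccc3c2)c1`: 60000 nM
- compound 2, `CCOC(=O)c1cccc(-c2ccc3c(c2)CCN3)c1`: 120000 nM

Both numbers come from an assay on COS-7 cells for inhibition of patatin-like phospholipase domain-containing protein 2 (Mus musculus); a lower number here means a stronger inhibitor, a higher number a weaker inhibitor. Compound 1 gives 60000 nM and compound 2 gives 120000 nM; the gap between them lies within the usual scatter of this assay, so compound 1 cannot be set apart from compound 2 on these two numbers, and both stand at the weak end of what this assay reports.

The next compound in the series is compound 3, `CCOC(=O)c1cccc(-c2ccc3c(ccn3C)c2)c1`. Relative to compound 1 the change is methyl in place of hydrogen on an aromatic nitrogen; the rest of the shared core and the ester-bearing ring are unchanged.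

Going by the values given here, no measured pair shows this kind of step, so there is nothing to scale it against. With compound 1 already at 60000 nM, the expectation is a step from compound 1 to compound 3 of a 1.3-fold higher number from compound 1 to compound 3 (0.12 log units; within the scatter), of small size and not clearly beyond the scatter in either direction. Compound 3 is therefore estimated at 80000 nM, with a plausible range from 25000 nM to 250000 nM.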

Compound 3, half-maximal inhibitory concentration: 75000 nM
For compound 3 the middle estimate is 1.1-fold (0.03 log units) above the measured one; the measured number falls inside the stated range.
By their numbers in this assay, from the lowest: compounds 1, 3 and 2 (each within the scatter of the next).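

In this assay, going by these compounds alone, methyl in place of hydrogen on an aromatic nitrogen gives a 1.3-fold higher number from compound 1 to compound 3 (0.10 log units; within the scatter), which is the first single-place step that can be read, and compound 3 cannot be set apart from compound 1. On this one step, the hydrogen on that aromatic nitrogen of the five-membered aromatic ring is not needed to keep a number level with that of compound 1, and a single added carbon is accepted at this position, although this says so only at the weak end of what this assay reports. No supporting measurement bears on why the step comes out this way.

Open, as far as these compounds go, is whether anything larger on that aromatic nitrogen, such as a longer chain or a chain ending in an amine or a carboxylic acid, would give a number that stands clearly apart from compound 1 and compound 3. Also open, from the compounds shown here alone, is whether the ethyl ester matters at all, for instance whether a carboxylic acid or an amide in its place would reach a stronger range in this assay than this small step can show.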